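This account rests on a few compounds, and the source may have more. Where it says the series, first, only, none or still open, it means among the compounds named here.

The measured compounds:
Compound 1 `Cn1cnc(CN2CCN(c3cccc4[nH]c(-c5ccc(C(C)(C)C)cc5)nc34)CC2)c1` gives 98 nM in an assay on isolated protein for displacement of a labelled ligand from Gonadotropin-releasing hormone receptor (Rattus norvegicus); a higher number here means a weaker inhibitor, a lower number a stronger inhibitor.
Compound 2 `CCc1nc(C)c(CN2CCN(c3cccc4[nH]c(-c5ccc(C(C)(C)C)cc5)nc34)CC2)s1` gives 120 nM in this assay.
Compound 3 `CCc1nc(CN2CCN(c3cccc4[nH]c(-c5ccc(C(C)(C)C)cc5)nc34)CC2)cn1C` gives 78 nM in this assay.

Among these three numbers compound 1 stands second highest; its nearest neighbour is compound 2, with a 1.2-fold higher number from compound 1 to compound 2 (0.09 log units; within the scatter), and the furthest is compound 3, with a 1.3-fold lower number from compound 1 to compound 3 (0.10 log units; within the scatter). Both steps lie within the scatter, so none of the three compounds can be set above or below the others on these numbers, and the step of a 1.5-fold lower number from compound 2 to compound 3 (0.19 log units; within the scatter) is likewise within the scatter.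

Compound 4 `CCCCc1nc(CN2CCN(c3cccc4[nH]c(-c5ccc(C(C)(C)C)cc5)nc34)CC2)cn1C` has not yet been measured in this assay. It differs from compound 1 by butyl in place of hydrogen on an aromatic carbon. The measured step that bears on this change is a 1.3-fold lower number from compound 1 to compound 3 (0.10 log units; within the scatter), where ethyl enters at the same aromatic carbon, and it stayed within the scatter. Going by the values given here, no measured compound carries butyl at this place, so the behaviour of the longer chain is not known from these data. Because a 1.3-fold lower number from compound 1 to compound 3 (0.10 log units; within the scatter) stayed within the scatter, the step of a 1.2-fold lower number from compound 1 to compound 4 (0.09 log units; within the scatter) is expected to stay within the scatter as well. Compound 4 is therefore estimated to give 80 nM, with a range from 30 nM to 220 nM.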

Compound 4, half-maximal inhibitory concentration: 58 nM
Beside the measured number, compound 4's estimate is 1.4-fold (0.14 log units) above it, within the range that was stated.
By their numbers in this assay, from the lowest: compounds 4, 3, 1 and 2 (each within the scatter of the next, the first and the last beyond it).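

In this assay, the aromatic carbon between two ring nitrogen atoms carries a butyl group with no step beyond the scatter, either against hydrogen (a 1.7-fold lower number from compound 1 to compound 4 (0.23 log units; within the scatter)) or against ethyl (a 1.3-fold lower number from compound 3 to compound 4 (0.13 log units; within the scatter)). The earlier compounds shown here showed this only for ethyl, so the tolerated substituent at this place now extends to the four-carbon chain, and compound 1, compound 3 and compound 4 still cannot be set apart on these numbers. Going by these compounds alone, the only step beyond the scatter is a modest one (a 2.1-fold lower number from compound 2 to compound 4 (0.32 log units; beyond the scatter)), where 2-butyl-1-methyl-1H-imidazol-4-yl stands in place of 2-ethyl-4-methyl-1,3-thiazol-5-yl, and nothing measured here offers an explanation for it.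

From the compounds shown here alone, what a hexyl chain, a cyclopropyl or phenyl ring, or an amine or carboxylic acid at the end of the chain would do at this carbon stays open. The step between compound 2 and compound 4 also changes the ring and the chain together, and no compound shown carries butyl in place of ethyl on the 1,3-thiazol-5-yl group, so the two changes remain unseparated.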